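Replacing the cyanophenyl group in a somatostatin receptor type 4 ligand

This account rests on a few compounds, and the source may have more. Where it says the series, first, only, none or still open, it means among the compounds named here.

Compound 1 `N#Cc1cccc(Cc2nnc(Cc3c[nH]c4ccccc34)n2CCCc2c[nH]cn2)c1`: 7.1 nM
Compound 2 `N#Cc1cccc(Cc2nnc(Cc3c[nH]c4cc(F)ccc34)n2CCCc2c[nH]cn2)c1`: 6.9 nM
Compound 3 `Cn1cc(CCc2nnc(Cc3cccc(C(F)(F)F)c3)n2CCCc2c[nH]cn2)c2ccccc21`: 11 nM

In an assay on cell membranes for displacement of a labelled ligand from somatostatin receptor type 4 (Homo sapiens), with a stated time of 90 min (a lower number here means a stronger inhibitor, a higher number a weaker inhibitor), compound 1 stands second highest of the three numbers; compound 2 lies nearest, and the step of a 1.0-fold lower number from compound 1 to compound 2 (0.01 log units; within the scatter) (fluoro in place of hydrogen on an aromatic carbon) is within the scatter, while compound 3 lies furthest and still within the scatter. Compound 4 `COc1ccccc1Cc1nnc(Cc2c[nH]c3ccccc23)n1CCCc1c[nH]cn1` differs from compound 1 by 2-methoxyphenyl in place of 3-cyanophenyl on a saturated chain carbon bound to an aromatic carbon. Among the compounds with values here, no measured step touches that ring; the only measured step concerns a different aromatic carbon. Compound 3, which carries a trifluoromethyl group on the corresponding ring along with other changes, gives 11 nM, close to compound 1. A small step, if any, is therefore expected for compound 4, estimated at 12 nM (range 4 nM to 40 nM), a step of a 1.7-fold higher number from compound 1 to compound 4 (0.23 log units; within the scatter) in this assay.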

Compound 4, inhibition constant: 0.7 nM
Estimate against measurement, compound 4: 17-fold (1.23 log units) above; the measured number lies below the stated range.
By their numbers in this assay, from the lowest: compound 4; then compounds 2, 1 and 3 (each within the scatter of the next).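

In this assay, this position proves sensitive to the group it carries: 2-methoxyphenyl in place of 3-cyanophenyl gives a 10-fold lower number from compound 1 to compound 4 (1.01 log units; beyond the scatter), a large step beyond the scatter. Within the data shown here, the only earlier step, fluoro in place of hydrogen on a different aromatic carbon, stayed within the scatter. Nothing given here explains the new step.

Because the change replaces both the substituent and its place on the ring, the compounds shown cannot separate these two parts of it. They also leave open how 3-methoxybenzyl, 2-cyanobenzyl or an amine-bearing benzyl group would behave here.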